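The source may hold more compounds than are shown below. What is called first, only, known or untested is meant among the compounds shown, and "the series" means these compounds.

Compound 3 `CCC(C(=O)N1CCN(c2cccc(C)c2)CC1)N1C(=O)CCC1=O` is one of three measured members of a small series built on a shared core. In a functional assay on the whole organism (strain Swiss) with Mus musculus as the target, in the maximal electroshock model, with a stated time of 1 h, at a dose of 100 mg/kg by the intraperitoneal route (on this read-out lower numbers stand for a weaker effect and higher numbers for a stronger effect at the one dose given), compound 3 gives 0%. Its two measured companions sit at the same level: compound 1 `CC(C(=O)N1CCN(c2ccccc2)CC1)N1C(=O)CCC1=O` gives 0%, and compound 2 `CC(C(=O)N1CCN(c2cccc(F)c2)CC1)N1C(=O)CCC1=O` gives 0%. Within the data shown here, the only step between neighbours that differ in one place, no change at the digits printed from compound 1 to compound 2 (within the scatter), shows that fluoro in place of hydrogen on an aromatic carbon left the read-out where it was.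

Compound 4 `Cc1cccc(N2CCN(C(=O)C(C)N3C(=O)CCC3=O)CC2)c1` has not been measured. It differs from compound 3 by hydrogen in place of methyl on a saturated chain carbon, two bonds along the chain from an amide-type nitrogen in a ring and a carbonyl carbon. Among the measured compounds shown here, no measured step concerns this kind of change; the single step from compound 1 to compound 2 lies on the aromatic ring, not on the saturated chain, so it offers no guide beyond showing a flat series. With every measured compound at the same floor value, the expectation for compound 4 is no movement beyond the scatter, an expected step of no change at the digits printed from compound 3 to compound 4 (within the scatter). The estimate for compound 4 is 0%, expected to fall between 0% and 10%.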

Compound 4, a percentage reported as activity, at one dose (the size of the read-out at that dose, not a potency): 0%
Compound 4: middle estimate and measured number agree at the digits printed, within the range that was stated.
By their numbers in this assay, from the lowest: compounds 1, 2, 3 and 4 (each within the scatter of the next).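

In this assay there is no change at the digits printed from compound 3 to compound 4 (within the scatter) when ethyl gives way to methyl at this saturated chain carbon, the first measured change away from the aromatic ring. The methyl on the aromatic ring can now be read as well, with no change at the digits printed from compound 2 to compound 4 (within the scatter) for methyl in place of fluoro and no change at the digits printed from compound 1 to compound 4 (within the scatter) for a methyl group on the aromatic ring where only hydrogen stood. All four compounds sit at the bottom of the scale, so neither position has yet shown any effect on the read-out, and nothing available explains this flat result.

The compounds shown leave open whether a longer chain or a benzyl group at this chain carbon would lift the read-out off the floor. They also leave open whether a methoxy group or a chlorine on the aromatic ring would do so.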